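Phenyl to pyridin-3-yl on the ether of compound 3

The source may report more compounds than this note shows. Statements on the series, on what has been measured and on what is new or still open speak of the compounds shown alone.

Three compounds share one core and differ only in the group carried on the triazole. Compound 1 `O=c1cc(-n2cc(-c3ccccc3)nn2)c2cc(Br)ccc2o1` bears a phenyl and in a functional assay on SW480 cells (Homo sapiens) for antiproliferative activity, read by MTT assay, with a stated time of 48 h (on this read-out lower numbers stand for stronger inhibition and higher numbers for weaker inhibition), compound 1 gives 6660 nM. Compound 2 `O=c1cc(-n2cc(CNc3ccccc3)nn2)c2cc(Br)ccc2o1` carries an anilinomethyl instead, and in this assay compound 2 gives 18400 nM. Compound 3 `O=c1cc(-n2cc(COc3ccccc3)nn2)c2cc(Br)ccc2o1` has a phenoxymethyl, and in this assay compound 3 gives 4990 nM, the lowest of the three numbers: compound 1 lies within the scatter of it, while compound 2 stands apart (a 3.7-fold lower number from compound 2 to compound 3 (0.57 log units; beyond the scatter)). The measured steps concern the linker only: a 2.8-fold higher number from compound 1 to compound 2 (0.44 log units; beyond the scatter) and a 1.3-fold lower number from compound 1 to compound 3 (0.13 log units; within the scatter).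

Compound 4 `O=c1cc(-n2cc(COc3cccnc3)nn2)c2cc(Br)ccc2o1` keeps the phenoxymethyl linker and changes the ring at its end: pyridin-3-yl in place of phenyl on an oxygen on a saturated carbon. For the measured compounds named here, no measured step touches this ring, so nothing among the three compounds speaks for a change beyond the scatter in this assay. The expected step is therefore a 1.0-fold higher number from compound 3 to compound 4 (0.00 log units; within the scatter), and for compound 4 the expected value in this assay is 5000 nM with a range from 2500 nM to 10000 nM.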

Compound 4, half-maximal inhibitory concentration: 39800 nM
Beside the measured number, compound 4's estimate is 8.0-fold (0.90 log units) below it; measured number above the stated range.
By their numbers in this assay, from the lowest: compounds 3 and 1 (each within the scatter of the next); then compound 2; then compound 4.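

The ring at the end of the ether proves sensitive in this assay: pyridin-3-yl in place of phenyl, a swap that keeps the count of heavy atoms and adds one hydrogen-bond acceptor, gives an 8.0-fold higher number from compound 3 to compound 4 (0.90 log units; beyond the scatter), a larger step than any the linker changes gave. With the pyridin-3-yl end, the ether linker no longer holds its place among the three earlier compounds, as a 2.2-fold higher number from compound 2 to compound 4 (0.34 log units; beyond the scatter) and a 6.0-fold higher number from compound 1 to compound 4 (0.78 log units; beyond the scatter) show. Nothing given here explains this step.

The compounds shown leave open whether pyridin-2-yl or pyridin-4-yl on the same oxygen would give a step of the same size, and whether a 4-fluorophenyl or 4-methoxyphenyl there would move the number in either direction. They also leave open whether pyridin-3-yl would have the same effect on the anilinomethyl linker or directly on the triazole.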